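Swapping Fluoro for Chloro on the Aniline Ring

A few compounds are considered here, and "the series" means these few. Any claim that something is new, unique, unknown or untested is made for them only; others in the source may bear on it.

The measured compounds and their values:
compound 1 `O/N=C(/Nc1cccc(Cl)c1)c1ccc2occc2c1`: 1500 nM
compound 2 `OCc1cc2cc(/C(=N\O)Nc3cccc(Cl)c3)ccc2o1`: 5900 nM
compound 3 `O/N=C(/Nc1cccc(F)c1)c1ccc2oc(COCC3CC3)cc2c1`: 8000 nM

All three were tested in an assay on tissue (HeLa cells) for inhibition of Indoleamine 2,3-dioxygenase 1 (Homo sapiens), read by spectrophotometry; on this read-out higher numbers stand for weaker inhibition and lower numbers for stronger inhibition. Compound 3 lies beyond the usual scatter from compound 1, which gives 1500 nM, but within the scatter of compound 2, so compound 3 and compound 2 cannot be ranked against each other on these numbers.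

For the measured compounds named here, the only one-change step among the measured compounds is a 3.9-fold higher number from compound 1 to compound 2 (0.59 log units; beyond the scatter). It concerns a hydroxymethyl group on the shared core, a different place from the change considered here, so it does not bear directly on it.

Compound 4 `O/N=C(/Nc1cccc(Cl)c1)c1ccc2oc(COCC3CC3)cc2c1` differs from compound 3 in one place: chloro in place of fluoro on an aromatic carbon. No measured pair differs only in this way, so nothing shown speaks for a large shift in either direction. The expectation is therefore a step of a 1.2-fold lower number from compound 3 to compound 4 (0.09 log units; within the scatter) in this assay, which is no change beyond the scatter. Compound 4 is expected to give 6500 nM, with a range from 2500 nM to 16000 nM, and this estimate rests on compound 3 alone, which gives 8000 nM.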

Compound 4, half-maximal inhibitory concentration: 17600 nM
For compound 4 the middle estimate is 2.7-fold (0.43 log units) below the measured one, and the stated range ends below it.
By their numbers in this assay, from the lowest: compound 1; then compounds 2 and 3 (each within the scatter of the next); then compound 4.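

In this assay, the aromatic carbon carrying the halogen is not indifferent to the choice of halogen: going from 3-fluorophenyl to 3-chlorophenyl gives a 2.2-fold higher number from compound 3 to compound 4 (0.34 log units; beyond the scatter), a modest but real loss of inhibition when the (cyclopropylmethoxy)methyl group is present. For the compounds shown here, with chloro held constant, the new compound also extends the picture at the other site of change, since adding cyclopropylmethyl to the oxygen of the hydroxymethyl group gives a 3.0-fold higher number from compound 2 to compound 4 (0.47 log units; beyond the scatter), and the whole (cyclopropylmethoxy)methyl group in place of hydrogen gives a 12-fold higher number from compound 1 to compound 4 (1.07 log units; beyond the scatter), the one large step in this set. No measurement offered here explains why either change weakens inhibition.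

Whether chloro in place of fluoro produces a similar step without the (cyclopropylmethoxy)methyl group remains open, as the compounds shown contain this halogen swap only in the single pair of compound 3 and compound 4. It is also unknown how bromo, methyl or a nitrile on the same aromatic carbon would compare, or whether an amine or a carboxylic acid at the end of the chain would recover any of the lost inhibition.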